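The source may hold more compounds than are shown below. What is called first, only, known or untested is meant among the compounds shown, and "the series" means these compounds.

Among the compounds with values here, compound 2 `COc1ccc(/C=C\c2cc(OC)c(OC)c(OC)c2)cc1OCc1ccc(CO)cc1` is the only compound of this pair that gives a number in a functional assay on HepG2 cells (Homo sapiens) for antiproliferative activity, read by CCK-8 assay, with a stated time of 48 h (on this read-out lower numbers stand for stronger inhibition and higher numbers for weaker inhibition), where compound 2 reaches 2400 nM. Compound 1 `COc1ccc(/C=C\c2cc(OC)c(OC)c(OC)c2)cc1OCc1ccc(CN2CCCC[C@H]2C(=O)O)cc1` differs only in the group on a saturated chain carbon bound to an aromatic carbon, and in this assay compound 1 gives > 10000 nM, which is a limit of the assay and not a number. The step of an at least 4.1-fold lower number from compound 1 to compound 2 (0.61 log units; beyond the scatter) shows that hydroxy in place of 2-carboxypiperidin-1-yl brought the number down, with its true size open because of the limit of > 10000 nM in this assay, at which 1 of the 2 values shown sits.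

Compound 3 `COc1ccc(/C=C\c2cc(OC)c(OC)c(OC)c2)cc1OCc1ccc(CN2CCCCC2C(=O)NCCN)cc1` is not yet measured. Relative to compound 2 the change is 2-((2-aminoethyl)carbamoyl)piperidin-1-yl in place of hydroxy on a saturated chain carbon bound to an aromatic carbon. It touches the same place that was varied between compounds 1 and 2, and once more a piperidinyl group stands where compound 2 carries hydroxy. Within the data shown here, the only measured step, an at least 4.1-fold lower number from compound 1 to compound 2 (0.61 log units; beyond the scatter), ran toward a lower number when the piperidinyl was removed, so restoring one is expected to raise the number by at least a modest step. For compound 3 the expected value in this assay is 8000 nM, ranging from 3000 nM to 20000 nM. This expectation corresponds to the step of a 3.3-fold higher number from compound 2 to compound 3 (0.52 log units; beyond the scatter), and compound 3 may well end at the limit of the assay as well.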

Compound 3, half-maximal inhibitory concentration: 4800 nM
The estimate for compound 3 lay 1.7-fold (0.22 log units) above the measured number, and the stated range covers the measured number.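

At this place, on a saturated chain carbon bound to an aromatic carbon, a group far larger than hydroxy can stand without a clear change in this assay: the exchange gives a 2.0-fold higher number from compound 2 to compound 3 (0.30 log units; within the scatter). The piperidine ring alone therefore does not account for the weak result of compound 1, and the group carried on that ring matters, as exchanging 2-carboxypiperidin-1-yl for 2-((2-aminoethyl)carbamoyl)piperidin-1-yl gives an at least 2.0-fold lower number from compound 1 to compound 3 (0.31 log units; beyond the scatter). The true size of this last step stays open because compound 1 gives a limit and not a number: the limit of > 10000 nM in this assay, at which 1 of the 3 values shown sits.

The compounds shown do not tell whether the amide or the terminal amine of the 2-aminoethyl chain matters more for this recovery. A plain piperidin-1-yl group, a simple primary amide on the ring, or a longer chain ending in an amine would begin to separate these parts, and a methyl ester in place of the carboxylic acid would test that end of the comparison.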